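From a Difluorophenyl Amide to a Benzyl Carbamate

This account rests on a few compounds, and the source may have more. Where it says the series, first, only, none or still open, it means among the compounds named here.

Among the compounds with values here, in an assay on CHO-K1 cells for displacement of a labelled ligand from prostaglandin E2 receptor EP1 subtype (Homo sapiens) (a higher number here means a weaker inhibitor, a lower number a stronger inhibitor), compound 1 `CNC(=O)c1cc(C)n(Cc2cc(Cl)ccc2OCc2ccccc2)n1` gives 100 nM, while compound 2 `Cc1cc(NC(=O)c2c(F)cccc2F)nn1Cc1cc(Cl)ccc1OCc1ccccc1` gives 12.6 nM, the lower of the two numbers; the only measured step is a 7.9-fold lower number from compound 1 to compound 2 (0.90 log units; beyond the scatter), which exchanged the whole substituent on that aromatic carbon. Compound 3 `Cc1cc(NC(=O)OCc2ccccc2)nn1Cc1cc(Cl)ccc1OCc1ccccc1` differs from compound 2 by benzyloxy in place of 2,6-difluorophenyl on a carbonyl carbon. Within the data shown here, no measured step touches the carbonyl substituent alone, so that step bears only loosely here. For compound 3 a modest drift toward a higher number is expected, a 2.4-fold higher number from compound 2 to compound 3 (0.38 log units; beyond the scatter). Compound 3 is estimated in this assay at 30 nM, within 8 nM to 120 nM.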

Compound 3, half-maximal inhibitory concentration: 79.4 nM
Estimate against measurement, compound 3: 2.6-fold (0.42 log units) below; the range from low to high includes it.
By their numbers in this assay, from the lowest: compound 2; then compounds 3 and 1 (each within the scatter of the next).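

Placing benzyloxy on the carbonyl carbon gives a 6.3-fold higher number from compound 2 to compound 3 (0.80 log units; beyond the scatter) in this assay, so the amide-type nitrogen and carbonyl kept in both compounds do not alone preserve the lower number of compound 2. Against methylcarbamoyl, (benzyloxycarbonyl)amino gives a 1.3-fold lower number from compound 1 to compound 3 (0.10 log units; within the scatter) and is not separated from it by this assay. Nothing available explains either step.

Open, on these data alone, is whether an unsubstituted phenyl on that carbonyl carbon would match 2,6-difluorophenyl, which would test whether the fluorine atoms matter. Also open, as far as these compounds go, is how a simple alkyl chain or a pyridine ring would fare there.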